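The source may hold more compounds than are shown below. What is called first, only, known or untested is meant among the compounds shown, and "the series" means these compounds.

Of the compounds shown here, two built on one shared core have been tested in an ADME assay on MT4 cells (Homo sapiens) for cytotoxicity, read by MTT assay, with a stated time of 5 days; on this read-out higher numbers stand for lower toxicity in this test and lower numbers for higher toxicity in this test. Compound 1 `O=C(CSc1snnc1-c1ccc(Br)cc1Br)Nc1ccccn1` carries a pyridin-2-yl group on its amide-type nitrogen, and in this assay compound 1 gives 42400 nM. Compound 2 `O=C(CSc1snnc1-c1ccc(Br)cc1Br)Nc1ccccc1[N+](=O)[O-]` carries a 2-nitrophenyl group in that place. For compound 2 this assay reports only a limit, > 235000 nM, and not a number. Among the measured compounds shown here, the one measured step is an at least 5.5-fold higher number from compound 1 to compound 2 (0.74 log units; beyond the scatter). Its end point is the limit of > 235000 nM in this assay, at which 1 of the 2 values shown sits. Compound 2 therefore stands at the top of the numbers seen so far, although its true position is not known.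

Compound 3 `Cc1ccc(NC(=O)CSc2snnc2-c2ccc(Br)cc2Br)c([N+](=O)[O-])c1` differs from compound 2 by a single change: methyl in place of hydrogen on an aromatic carbon. For the measured compounds named here, the only measured step concerns a different change, the exchange of the whole aromatic group on the amide-type nitrogen, and says nothing about a methyl group alone. Going by the values given here, no measured step points to a shift beyond the scatter, so for compound 3 the expected step is a step that the limit leaves unreadable from compound 2 to compound 3. Compound 3 is estimated at 300000 nM, with a range from 120000 nM to 700000 nM, and a good chance that this assay again reports only a limit.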

Compound 3, half-maximal cytotoxic concentration: > 229000 nM
Compound 3 ended at the assay's limit; the forecaster's own chance of this, stated with the estimate: 70%; the middle value does not contradict the limit.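

In this assay compound 2 gives only a limit, > 235000 nM, and not a number. Compound 3 also gives only a limit, > 229000 nM, so no step can be read between these two compounds. Where the true values of compound 2 and compound 3 lie, and whether methyl in place of hydrogen changes this read-out at all, stays open.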